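The source may report more compounds than this note shows. Statements on the series, on what has been measured and on what is new or still open speak of the compounds shown alone.

The three compounds measured so far in a functional assay on MGC-803 cells (Homo sapiens) for inhibition, read by sulforhodamine B assay; a higher number here means a weaker inhibitor, a lower number a stronger inhibitor:

- compound 1, `Cc1ccc(NC2=CC(=O)c3c(nc4n3[C@H]3OC[C@@H](O)[C@H]3OC4)C2=O)cc1C`, gives 1050 nM
- compound 2, `CCOc1ccc(NC2=CC(=O)c3c(nc4n3[C@H]3OC[C@@H](O)[C@H]3OC4)C2=O)cc1`, gives 2090 nM
- compound 3, `COc1ccccc1NC1=CC(=O)c2c(nc3n2[C@H]2OC[C@@H](O)[C@H]2OC3)C1=O`, gives 1670 nM

All three share the same core and differ only in the group carried on the amine nitrogen. Compound 3 holds the second highest of the three numbers, but every step among them lies within the scatter: a 2.0-fold higher number from compound 1 to compound 2 (0.30 log units; within the scatter), a 1.6-fold higher number from compound 1 to compound 3 (0.20 log units; within the scatter), and a 1.3-fold lower number from compound 2 to compound 3 (0.10 log units; within the scatter). On these numbers the three compounds cannot be told apart.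

Compound 4, `O=C1C(NC2CCCC2)=CC(=O)c2c1nc1n2[C@H]2OC[C@@H](O)[C@H]2OC1`, has not yet been measured. It differs from compound 3 in one place: cyclopentyl in place of 2-methoxyphenyl on an amine nitrogen. Within the data shown here, none of the measured steps covers a change of this kind: each of them swapped one substituted phenyl for another, and each stayed within the scatter. There is therefore no direct guide to how the move to cyclopentyl will read in this assay. The expectation can rest only on the narrow band in which compound 1, compound 2 and compound 3 sit, and since the new group leaves that family of phenyl groups altogether, the range has to be wide. Compound 4 is estimated at 2500 nM, with a range from 800 nM to 8000 nM. The step this estimate implies, a 1.5-fold higher number from compound 3 to compound 4 (0.18 log units; within the scatter), is expected to be small compared with the uncertainty around it.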

Compound 4, half-maximal inhibitory concentration: > 16000 nM
Compound 4 gave a limit, no number; the forecaster's own chance of this, stated with the estimate: 10%; at least 6.4-fold (0.80 log units) between middle value and limit.
By their numbers in this assay, from the lowest: compounds 1, 3 and 2 (each within the scatter of the next). At a limit, above all of these: compound 4.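

In this assay, compound 4 carries a limit and not a number: the limit of > 16000 nM in this assay, at which 1 of the 4 values shown sits.

The swaps from one substituted phenyl to another stayed within the scatter, but replacing the phenyl group with cyclopentyl on this amine nitrogen moves the reading beyond it, with an at least 9.5-fold higher number from compound 3 to compound 4 (0.98 log units; beyond the scatter) and an at least 7.6-fold higher number from compound 2 to compound 4 (0.88 log units; beyond the scatter) and also an at least 15-fold higher number from compound 1 to compound 4 (1.18 log units; beyond the scatter) as the three steps. The position is therefore not indifferent to the group it carries: the three compounds with a six-membered aromatic ring there all give numbers, while the one with a five-membered non-aromatic ring gives only a limit.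

What the compounds shown leave open is which part of the change matters, since cyclopentyl differs from the phenyl groups both in ring size and in having no aromatic ring. On these data alone, a cyclohexyl group on the same nitrogen would keep the six-membered size without the aromatic ring and so would separate the two, while how far compound 4 lies past its limit stays unknown.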